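The source may hold more compounds than are shown below. What is called first, only, known or untested is meant among the compounds shown, and "the series" means these compounds.

Four related acids are compared here, all built on one shared core. Compound 1 `O=C(O)CC(NS(=O)(=O)c1ccccc1)c1ccccc1` is the simplest. Compound 2 `CC(C)(C)c1ccc(C(CC(=O)O)NS(=O)(=O)c2ccccc2)cc1` differs from it by a tert-butyl group, and compound 3 `CC(C)(C)c1ccc(C(CC(=O)O)NS(=O)(=O)c2ccc(F)cc2)cc1` differs from compound 2 by fluoro in place of hydrogen on an aromatic carbon. Compound 4 `O=C(O)CC(NS(=O)(=O)c1ccccc1)c1ccccc1F` has not yet been tested.

In a functional assay on MDA-MB-231 cells (Homo sapiens) for antiproliferative activity, read by MTT assay, with a stated time of 24 h (on this read-out higher numbers stand for weaker inhibition and lower numbers for stronger inhibition), compound 1 gives > 100000 nM, which is a limit of the assay and not a number. Compound 2 likewise gives only a limit, > 100000 nM. Compound 3 gives 66200 nM.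

The two cores differ by hydrogen in place of tert-butyl on an aromatic carbon, and the step that the two limits leave unreadable from compound 1 to compound 2 because of the limit of > 100000 nM in this assay, at which 2 of the 3 values shown sit. The fluoro change made an at least 1.5-fold lower number from compound 2 to compound 3 (0.17 log units; that floor lies within the scatter), a step whose floor is small.

Compound 4 differs from compound 1 by fluoro in place of hydrogen on an aromatic carbon. This is the same kind of change as from compound 2 to compound 3, but not the same: there the fluoro is para to a large group, here it is ortho to a large group.

The expectation for compound 4 rests on compound 1 sitting at a limit, > 100000 nM, and on the modest floor of the fluoro step in compound 3. Compound 4 is therefore expected near 120000 nM, somewhere between 40000 nM and 350000 nM. The estimated step is a step that the limit leaves unreadable from compound 1 to compound 4, and a second limit is judged more likely than a readable number.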

Compound 4, half-maximal inhibitory concentration: > 100000 nM
Compound 4 gave a limit, no number; the forecaster's own chance of this, stated with the estimate: 65%; the middle value lies beyond the limit too.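

In this assay, compound 1 and compound 4 both end at a limit and not at a number, so the step between them cannot be read: the limit of > 100000 nM in this assay, at which 3 of the 4 values shown sit.

The compounds shown leave open whether the change from phenyl to 2-fluorophenyl alters antiproliferative activity at all, and whether fluoro on this shared core could ever give a readable number without the tert-butyl group.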